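A hydroxy group in place of bromo

A few compounds are considered here, and "the series" means these few. Any claim that something is new, unique, unknown or untested is made for them only; others in the source may bear on it.

Measured in a functional assay on HepG2 cells (Homo sapiens) for inhibition, read by MTT assay, with a stated time of 72 h; a higher number here means a weaker inhibitor, a lower number a stronger inhibitor:
compound 1 `COc1ccc(-c2nnc(SCCCN3CCN(c4nc5ccccc5o4)CC3)o2)cc1`: 66100 nM
compound 2 `Clc1ccc(-c2nnc(SCCCN3CCN(c4nc5ccccc5o4)CC3)o2)cc1`: 121000 nM
compound 3 `Brc1ccc(-c2nnc(SCCCN3CCN(c4nc5ccccc5o4)CC3)o2)cc1`: 67500 nM

In this assay, compound 3 gives 67500 nM, which lies within the usual scatter of the other two values, so it holds no clear rank among them. The next structure is compound 4 `Oc1ccc(-c2nnc(SCCCN3CCN(c4nc5ccccc5o4)CC3)o2)cc1`, where hydroxy takes the place of bromo on an aromatic carbon, para to a large group: hydroxy in place of bromo on an aromatic carbon.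

For the measured compounds named here, the steps that bear on this change are the other swaps at this same place. Replacing methoxy with chloro gave a 1.8-fold higher number from compound 1 to compound 2 (0.26 log units; within the scatter), replacing methoxy with bromo gave a 1.0-fold higher number from compound 1 to compound 3 (0.01 log units; within the scatter), and replacing chloro with bromo gave a 1.8-fold lower number from compound 2 to compound 3 (0.25 log units; within the scatter). All three stay within the scatter, but none of them involves a hydroxy group, so they guide this change only indirectly. No clear shift in either direction is therefore expected, and the estimated move is a 1.0-fold higher number from compound 3 to compound 4 (0.02 log units; within the scatter). The estimate for compound 4 is 70000 nM, with an expected range of 30000 nM to 160000 nM.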

Compound 4, half-maximal inhibitory concentration: 502000 nM
Compound 4: the middle estimate sits 7.2-fold (0.86 log units) below what was measured; measured number outside the range, above it.
By their numbers in this assay, from the lowest: compounds 1, 3 and 2 (each within the scatter of the next); then compound 4.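

In this assay this place on the aromatic ring turns out to respond to its substituent, since methoxy, chloro and bromo all lay within the scatter of one another but hydroxy does not: swapping out bromo gives a 7.4-fold higher number from compound 3 to compound 4 (0.87 log units; beyond the scatter) and swapping out chloro gives a 4.1-fold higher number from compound 2 to compound 4 (0.62 log units; beyond the scatter) while losing only the methyl from the methoxy oxygen gives a 7.6-fold higher number from compound 1 to compound 4 (0.88 log units; beyond the scatter) as the result. For the compounds shown here, that last step shows that one methyl group on this oxygen separates compound 1 from the clearly weaker compound 4, the only compound here with a hydrogen-bond donor at this place. Nothing measured here gives a reason for this loss.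

The compounds shown leave open whether the loss is particular to hydroxy or would also come with an amine or a carboxylic acid at this place. They also leave open whether an ethoxy group would sit with methoxy.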